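Solubility notes: amino to methyl on the pyridine

This account rests on a few compounds, and the source may have more. Where it says the series, first, only, none or still open, it means among the compounds named here.

Among the measured compounds shown here, compound 1 `O=c1ncn(Cc2c(F)cc(F)cc2F)c2ccc(Oc3cccc(-c4ccc5[nH]ccc5c4)c3C(F)(F)F)cc12` and compound 2 `Nc1ccc(-c2cccc(Oc3ccc4c(c3)c(=O)ncn4Cc3c(F)cc(F)cc3F)c2C(F)(F)F)cn1` are the two compounds measured so far in a physicochemical assay for solubility, using the shake flask method, with a stated time of 24 h, at pH 6.8; a higher number here means a more soluble compound, a lower number a less soluble compound. In this assay compound 1 gives < 0.1 ug/mL, which is a limit of the assay and not a number. In this assay compound 2 gives < 0.1 ug/mL, again a limit and not a number. The step that the two limits leave unreadable from compound 1 to compound 2 is unreadable for that reason, since both values sit at the limit of < 0.1 ug/mL in this assay, at which 2 of the 2 values shown sit. Compound 2 therefore stands only at a limit, with no number to anchor it. Compound 3 `Cc1ccc(-c2cccc(Oc3ccc4c(c3)c(=O)ncn4Cc3c(F)cc(F)cc3F)c2C(F)(F)F)cn1` differs from compound 2 by methyl in place of amino on an aromatic carbon. For the measured compounds named here, no measured step bears on this change in a readable way, so no size can be taken from the series. Compound 3 is expected to remain at the limit, with an estimated step that the limit leaves unreadable from compound 2 to compound 3. For compound 3 the estimate in this assay is 0.05 ug/mL, within 0.01 ug/mL and 0.2 ug/mL.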

Compound 3, solubility: < 0.1 ug/mL
Compound 3: only a limit was reported; the forecaster's own chance of this, stated with the estimate: 85%; the middle value lies beyond the limit too.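

No new step can be read among compound 1, compound 2 and compound 3 in this assay, as each value is a limit and not a number: the limit of < 0.1 ug/mL in this assay, at which 3 of the 3 values shown sit. The compounds shown leave open how 1H-indol-5-yl, 6-aminopyridin-3-yl and 6-methylpyridin-3-yl rank in this assay, with no numerical value to anchor a comparison.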